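Cyclohexyl for 3-methoxyphenyl on a compound at the limit

The source may hold more compounds than are shown below. What is called first, only, known or untested is meant among the compounds shown, and "the series" means these compounds.

Compound 1 `COc1cccc(N2C(=O)COc3ccc(-c4cnc5ccccc5c4)cc32)c1` gives > 40000 nM in a functional assay on A549 cells (Homo sapiens) for antiproliferative activity, read by MTT assay, with a stated time of 72 h; on this read-out higher numbers stand for weaker inhibition and lower numbers for stronger inhibition
Compound 2 `COc1cccc(N2C(=O)COc3ccc(-c4cccc(NS(=O)(=O)c5ccc(F)cc5)c4)cc32)c1` gives > 40000 nM in this assay

Compound 1 gives only a limit and no number, > 40000 nM in this assay and nothing sharper. Among the compounds with values here, both measured compounds sit at the limit of > 40000 nM in this assay, at which 2 of the 2 values shown sit, and no step between them is known. Compound 3 `O=C1COc2ccc(-c3cnc4ccccc4c3)cc2N1C1CCCCC1` keeps the core of compound 1 and has cyclohexyl in place of 3-methoxyphenyl on an amide-type nitrogen in a ring and it remains unmeasured. The expected change is none beyond the scatter, an estimated at least 1.1-fold lower number from compound 1 to compound 3 (0.05 log units; that floor lies within the scatter) in this assay and no clear direction. Compound 3 is estimated at 35000 nM (expected range 10000 nM to 60000 nM).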

Compound 3, half-maximal inhibitory concentration: > 40000 nM
Compound 3 gave a limit, no number (the forecaster's own chance of this, stated with the estimate: 65%); at least 1.1-fold (0.05 log units) between middle value and limit.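

Within the data shown here, compound 1 and compound 3 both stand at a limit in this assay, so no step between them can be read. What cyclohexyl in place of 3-methoxyphenyl does to the read-out stays open, with every compound shown at one limit: the limit of > 40000 nM in this assay, at which 3 of the 3 values shown sit.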